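A 3-methoxyphenyl swap in a level series

The source may hold more compounds than are shown below. What is called first, only, known or untested is meant among the compounds shown, and "the series" means these compounds.

Compound 1 `O=C(CSc1nnc(-c2ccncc2)o1)N/N=C/c1ccc(F)cc1`: 13500 nM
Compound 2 `O=C(CSc1nnc(-c2ccncc2)o1)N/N=C/c1ccc(Br)cc1`: 19100 nM
Compound 3 `O=C(CSc1nnc(-c2ccncc2)o1)N/N=C/c1ccc(O)cc1`: 11700 nM

These three values come from a functional assay on MCF7 cells (Homo sapiens) for cytotoxicity, read by MTT assay, with a stated time of 48 h; on this read-out higher numbers stand for weaker inhibition and lower numbers for stronger inhibition. Swapping one group on the aromatic ring has so far moved the number very little: a 1.4-fold higher number from compound 1 to compound 2 (0.15 log units; within the scatter), a 1.2-fold lower number from compound 1 to compound 3 (0.06 log units; within the scatter) and a 1.6-fold lower number from compound 2 to compound 3 (0.21 log units; within the scatter). Compound 3 therefore stands level with compound 1 and compound 2, with no real gap between them.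

Compound 4 `COc1cccc(/C=N/NC(=O)CSc2nnc(-c3ccncc3)o2)c1` makes one change to compound 3: 3-methoxyphenyl in place of 4-hydroxyphenyl on a carbon with a double bond to nitrogen. Here 3-methoxyphenyl comes in place of 4-hydroxyphenyl on a carbon with a double bond to nitrogen. The three measured steps are the closest guide, as each also changes only a group on this ring. Among the measured compounds shown here, still, no measured compound carries a 3-methoxyphenyl group, so the evidence is indirect.

With all three steps inside the scatter, no step beyond the scatter is expected in this assay. The most sensible guess therefore sits among the three measured values rather than exactly on compound 3. The expected change is small: a 1.2-fold higher number from compound 3 to compound 4 (0.08 log units; within the scatter). Compound 4 is estimated at 14000 nM, with an expected range of 7000 nM to 28000 nM.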

Compound 4, half-maximal inhibitory concentration: 13800 nM
Beside the measured number, compound 4's estimate is 1.0-fold (0.01 log units) above it; low and high end bracket the measured number.
By their numbers in this assay, from the lowest: compounds 3, 1, 4 and 2 (each within the scatter of the next).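

The earlier compounds shown here all carried a 4-substituted ring (4-fluorophenyl, 4-bromophenyl and 4-hydroxyphenyl), while compound 4 alone carries 3-methoxyphenyl on the carbon with a double bond to nitrogen, and in this assay this change gives a 1.2-fold higher number from compound 3 to compound 4 (0.07 log units; within the scatter), a step within the scatter. The swap takes the group from 1 hydrogen-bond donor to 0 hydrogen-bond donors with no real shift in the number, so in this small set the donor on compound 3 is not required to keep the value level, and the comparisons with the halogen-bearing rings, a 1.4-fold lower number from compound 2 to compound 4 (0.14 log units; within the scatter) and a 1.0-fold higher number from compound 1 to compound 4 (0.01 log units; within the scatter), stay within the scatter as well. No further measurement bears on this result, so the data give no explanation for it.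

The compounds shown leave open whether a more different group on this ring, such as an amine, a carboxylic acid or a longer chain in place of the methoxy, would move the number at all. They also cannot separate the effect of the group from that of its place on the ring, which a pair such as 4-methoxyphenyl and 3-hydroxyphenyl could do.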